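A few compounds are considered here, and "the series" means these few. Any claim that something is new, unique, unknown or untested is made for them only; others in the source may bear on it.

Going by the values given here, only two compounds built on related cores have been read so far in a functional assay on MOLT-3 cells (Homo sapiens) for cytotoxicity, read by XTT assay; on this read-out lower numbers stand for stronger inhibition and higher numbers for weaker inhibition. Compound 1 (`COc1cc(O)c(C=O)c2c1[C@H](O)C[C@@H](c1ccccc1)O2`) gives 24300 nM, while compound 2 (`COc1c(C)c(OC)c2c(c1C=O)O[C@H](c1ccccc1)C[C@H]2O`) gives 57400 nM. That is the higher of the two numbers, and its gap to the other lies beyond the scatter. Compound 3 (`COc1c(C)c(OC)c2c(c1C)O[C@H](c1ccccc1)C[C@H]2O`) has methyl in place of formyl on an aromatic carbon of compound 2, and the difference is methyl in place of formyl on an aromatic carbon. Among the compounds with values here, no measured pair differs in one place only, so the data offer no direct guide to this swap. In this assay, no step beyond the scatter is expected, with only a slight lean toward weaker inhibition. The estimated change is a 1.2-fold higher number from compound 2 to compound 3 (0.09 log units; within the scatter). For compound 3, the expected value is 70000 nM, with an estimated range from 25000 nM to 170000 nM.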

Compound 3, half-maximal inhibitory concentration: 63500 nM
Beside the measured number, compound 3's estimate is 1.1-fold (0.04 log units) above it; low and high end bracket the measured number.
By their numbers in this assay, from the lowest: compound 1; then compounds 2 and 3 (each within the scatter of the next).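

In this assay, methyl in place of formyl on this aromatic carbon gives a 1.1-fold higher number from compound 2 to compound 3 (0.04 log units; within the scatter) and so leaves the two compounds within the scatter of each other. Going by these compounds alone, this is the first pair that differs in one place only. It shows that at this carbon, ortho to a fused ring and para to a methoxy group, losing the formyl group with its double bond and hydrogen-bond acceptor brings no step beyond the scatter. Nothing at hand bears on the reason for this result.

From the compounds shown here alone, whether an amine, a carboxylic acid or a longer chain on this carbon would also stay within the scatter remains open. So does whether the same swap of formyl for methyl would read alike on the core of compound 1.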